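From 4-Sulfamoylphenyl to 2-Methylpyridin-4-yl: an Expected Gain

The source may report more compounds than this note shows. Statements on the series, on what has been measured and on what is new or still open speak of the compounds shown alone.

Compound 1 `O=C(O)Cc1sc(CSc2ccccc2)nc1-c1ccc(Cl)cc1` and compound 2 `O=C(O)Cc1sc(CS(=O)(=O)c2ccc(Cl)cc2)nc1-c1ccc(Cl)cc1` mark the active end of this small set in an in vitro functional assay on HEK285-7 cells for antagonist activity at prostaglandin D2 receptor 2 (Homo sapiens), read by BRET and beta-arrestin recruitment; on this read-out lower numbers stand for stronger inhibition and higher numbers for weaker inhibition: compound 1 gives 450 nM and compound 2 gives 730 nM. Compound 3 `NS(=O)(=O)c1ccc(-c2nc(C(c3ccc(F)cc3)c3ccc(F)cc3)sc2CC(=O)O)cc1` stands apart. In this assay compound 3 reaches only a limit of the assay, > 100000 nM, so no number is known for it. That puts compound 3 at the limit of > 100000 nM in this assay, at which 1 of the 3 values shown sits.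

Compound 4 `Cc1cc(-c2nc(C(c3ccc(F)cc3)c3ccc(F)cc3)sc2CC(=O)O)ccn1` carries the same large group as compound 3 and the same carboxymethyl group, and differs from it in one place: 2-methylpyridin-4-yl in place of 4-sulfamoylphenyl on an aromatic carbon. Within the data shown here, no measured pair in this set shows this change on its own, so its size cannot be read from the data. Compound 3 is expected to leave the limit with this change, and the step of an at least 12-fold lower number from compound 3 to compound 4 (1.09 log units; beyond the scatter) is expected to be a clear gain beyond the scatter, though it starts from a limit and is uncertain. Compound 4 is expected to give about 8000 nM in this assay, within a range from 800 nM to 80000 nM.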

Compound 4, half-maximal inhibitory concentration: 53 nM
Beside the measured number, compound 4's estimate is 150-fold (2.18 log units) above it; measured number below the stated range.
By their numbers in this assay, from the lowest: compound 4; then compounds 1 and 2 (each within the scatter of the next). At a limit, above all of these: compound 3.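

On an aromatic carbon of the five-membered aromatic ring with 1 nitrogen and 1 sulfur, 2-methylpyridin-4-yl in place of 4-sulfamoylphenyl gives an at least 1800-fold lower number from compound 3 to compound 4 (3.27 log units; beyond the scatter) in this assay. Among these compounds, with the large group and the carboxymethyl group held fixed, this position alone decides between a limit and a measured number, which the earlier compounds offered no single-place pair to show. Compound 3 is held at a limit, so the step gives only a minimum size: the limit of > 100000 nM in this assay, at which 1 of the 4 values shown sits.

This one pair cannot separate what the loss of 4-sulfamoylphenyl contributes from what the arrival of 2-methylpyridin-4-yl contributes. The compounds shown also leave open how a plain pyridin-4-yl, a phenyl or a 4-methylsulfonylphenyl group would read at this position, and so whether the methyl group or the ring nitrogen matters.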